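Bromine Added to the Benzyl Group of Compound 3

The compounds below may be only part of what the source reports. "The series", "measured", "known", "first", "only" and "open" are said of these compounds alone.

The compounds measured so far:
compound 1, `CCOc1cc(C2CCN(C)CC2)ccc1Nc1ncc2c(n1)N(Cc1ccccc1)[C@H](CC)C(=O)N2C`, 290 nM
compound 2, `CCOc1cc(C2CCN(C)CC2)ccc1Nc1ncc2c(n1)N(Cc1cccc(Br)c1)[C@H](CC)C(=O)N2C`, 540 nM
compound 3, `CCOc1cc(C(=O)NC2CCN(C)CC2)ccc1Nc1ncc2c(n1)N(Cc1ccccc1)[C@H](CC)C(=O)N2C`, 84 nM

In an assay on isolated protein for inhibition of serine/threonine-protein kinase PLK1 (Homo sapiens), read by Z'-LYTE, with a stated time of 60 min (a higher number here means a weaker inhibitor, a lower number a stronger inhibitor), compound 3 gives the lowest of the three numbers. Its nearest neighbour is compound 1, and the step from the two is a 3.5-fold lower number from compound 1 to compound 3 (0.54 log units; beyond the scatter); compound 2 lies furthest away, its number being higher than that of compound 3 by a gap beyond the scatter.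

Compound 4, `CCOc1cc(C(=O)NC2CCN(C)CC2)ccc1Nc1ncc2c(n1)N(Cc1cccc(Br)c1)[C@H](CC)C(=O)N2C`, differs from compound 3 in one place: bromo in place of hydrogen on an aromatic carbon. The same change has been made once before on this shared core, between compound 1 and compound 2, where the carbamoyl link is absent and the outcome was a 1.9-fold higher number from compound 1 to compound 2 (0.27 log units; within the scatter). Among the compounds with values here, that single precedent is the only guide, and it points to a step of no clear size, if any. On this basis compound 4 is expected to sit close to compound 3 in this assay, with a step estimated as a 1.7-fold higher number from compound 3 to compound 4 (0.22 log units; within the scatter) that leans toward a slightly higher number but stays within the usual scatter. The expected value for compound 4 is therefore 140 nM, with a range from 60 nM to 350 nM.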

Compound 4, half-maximal inhibitory concentration: 110 nM
Compound 4: the middle estimate sits 1.3-fold (0.10 log units) above what was measured, and the stated range covers the measured number.
By their numbers in this assay, from the lowest: compounds 3 and 4 (each within the scatter of the next); then compounds 1 and 2 (each within the scatter of the next).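

In this assay, bromo in place of hydrogen on the benzyl group now has a second reading, a 1.3-fold higher number from compound 3 to compound 4 (0.12 log units; within the scatter), so the step stays within the scatter on the core carrying the (1-methylpiperidin-4-yl)carbamoyl group as well, and the two readings agree: the same change on two cores in this assay, a 1.9-fold higher number (0.27 log units; within the scatter) from compound 1 to compound 2 and a 1.3-fold higher number (0.12 log units; within the scatter) from compound 3 to compound 4, 1.4-fold (0.15 log units) apart, within the scatter of two such steps. Within the data shown here, the swap of 1-methylpiperidin-4-yl for (1-methylpiperidin-4-yl)carbamoyl, until now seen only with an unsubstituted benzyl, also holds with 3-bromobenzyl in place, giving a 4.9-fold lower number from compound 2 to compound 4 (0.69 log units; beyond the scatter), and its size is matched on both cores: the same change on two cores in this assay, a 3.5-fold lower number (0.54 log units; beyond the scatter) from compound 1 to compound 3 and a 4.9-fold lower number (0.69 log units; beyond the scatter) from compound 2 to compound 4, 1.4-fold (0.15 log units) apart, within the scatter of two such steps. Across these four compounds, then, the size of each step shows no clear dependence on the other change, and the lower numbers follow the carbamoyl group whichever of the two benzyl groups is present.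

The compounds shown cover only bromo at this one place on the ring, so it stays open whether fluoro, methoxy, an amine or a carboxylic acid there would also leave the number within the scatter. On these data alone, it also stays open whether a group other than the (1-methylpiperidin-4-yl)carbamoyl group, such as a longer chain ending in an amine, would give a step of similar size.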